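A few compounds are considered here, and "the series" means these few. Any claim that something is new, unique, unknown or untested is made for them only; others in the source may bear on it.

Going by the values given here, in a functional assay on MDA-MB-231 cells (Homo sapiens), read by wound healing assay, with a stated time of 24 h (on this read-out lower numbers stand for stronger inhibition and higher numbers for weaker inhibition), compound 1 `CC(C)=CCC[C@H](C)c1ccc(C)c2c1OCN(CC1CCNCC1)C2` gives 8100 nM, the only exact number so far. Compound 2 `CC(C)=CCC[C@H](C)c1ccc(C)c(CNCCCCCO)c1O` is reported only as a limit of the assay, > 20000 nM. Compound 3 `CCOC(CCN1COc2c([C@@H](C)CCC=C(C)C)ccc(C)c2C1)OCC` keeps the core of compound 1 and changes one group: 2,2-diethoxyethyl in place of piperidin-4-yl on a saturated chain carbon bound to an amine nitrogen in a ring. Here 2,2-diethoxyethyl takes the place of piperidin-4-yl, on a saturated chain carbon bound to an amine nitrogen in a ring. No measured step sizes this swap, so the expectation is loose. A modest weakening is expected, and the estimated step, a 1.6-fold higher number from compound 1 to compound 3 (0.21 log units; within the scatter), may barely clear the usual scatter. For compound 3 the estimate is 13000 nM, with an expected range of 5000 nM to 35000 nM.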

Compound 3, half-maximal inhibitory concentration: 3100 nM
Estimate against measurement, compound 3: 4.2-fold (0.62 log units) above; measured number outside the range, below it.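

Swapping piperidin-4-yl for 2,2-diethoxyethyl, on a saturated chain carbon bound to an amine nitrogen in a ring, gives in this assay a 2.6-fold lower number from compound 1 to compound 3 (0.42 log units; beyond the scatter). This place therefore accepts an open chain with no ring and no hydrogen-bond donor, and inhibition does not suffer. Nothing measured here explains the gain.

Still open, from the compounds shown here alone, is whether the loss of the ring or the arrival of the two ethoxy groups drives the step. Also open, going by these compounds, is how a carboxylic acid or a plain longer alkyl chain would fare at this place.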